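This account rests on a few compounds, and the source may have more. Where it says the series, first, only, none or still open, it means among the compounds named here.

Going by the values given here, compound 3 `Cc1cc(C)cc(C(=O)Nc2cccc(-c3oc4cc(-c5ccc(F)cc5)ccc4c(=O)c3O)c2)c1` stands second highest of the three numbers so far in a functional assay on MDA-MB-231 cells (Homo sapiens) for antiproliferative activity, read by CCK-8 assay, with a stated time of 72 h (a lower number here means a stronger inhibitor, a higher number a weaker inhibitor), where compound 3 gives 11900 nM. Its nearest neighbour is compound 1 `O=C(Nc1cccc(-c2oc3cc(-c4ccc(F)cc4)ccc3c(=O)c2O)c1)c1ccc(Cl)cc1`, which in this assay gives 12800 nM, and the step of a 1.1-fold lower number from compound 1 to compound 3 (0.03 log units; within the scatter) lies within the scatter. Compound 2 `Cc1ccccc1C(=O)Nc1cccc(-c2oc3cc(-c4ccc(F)cc4)ccc3c(=O)c2O)c1` gives 4910 nM in this assay, and the step of a 2.4-fold higher number from compound 2 to compound 3 (0.38 log units; beyond the scatter) is modest but beyond the scatter.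

Compound 4 `N#Cc1ccc(C(=O)Nc2cccc(-c3oc4cc(-c5ccc(F)cc5)ccc4c(=O)c3O)c2)cc1` differs from compound 3 by one change: 4-cyanophenyl in place of 3,5-dimethylphenyl on a carbonyl carbon. Among the compounds with values here, the steps that bear on this change are those that swap one phenyl ring on the same carbonyl carbon for another. The step of a 1.1-fold lower number from compound 1 to compound 3 (0.03 log units; within the scatter) shows that exchanging 4-chlorophenyl for 3,5-dimethylphenyl made no difference beyond the scatter, and the step of a 2.6-fold lower number from compound 1 to compound 2 (0.42 log units; beyond the scatter) shows that only a modest gain is available within this set. Compound 4 is therefore expected to sit close to compound 3, with a step of a 1.0-fold higher number from compound 3 to compound 4 (0.00 log units; within the scatter) that is not expected to reach beyond the scatter. Compound 4 is estimated at 12000 nM in this assay, with a range from 5000 nM to 30000 nM.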

Compound 4, half-maximal inhibitory concentration: 11600 nM
For compound 4 the middle estimate is 1.0-fold (0.01 log units) above the measured one; the range from low to high includes it.
By their numbers in this assay, from the lowest: compound 2; then compounds 4, 3 and 1 (each within the scatter of the next).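

In this assay the step of a 1.0-fold lower number from compound 3 to compound 4 (0.01 log units; within the scatter) shows that on this carbonyl carbon a 4-cyanophenyl ring, with its triple bond and hydrogen-bond acceptor, gives a number within the scatter of the 3,5-dimethylphenyl ring. Going by these compounds alone, the step of a 1.1-fold lower number from compound 1 to compound 4 (0.04 log units; within the scatter) shows the same for cyano in place of chloro on the aromatic carbon, while the step of a 2.4-fold higher number from compound 2 to compound 4 (0.37 log units; beyond the scatter) leaves the 2-methylphenyl ring of compound 2 as the only one of the four rings set apart beyond the scatter. No measured evidence here accounts for these results.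

The compounds shown leave open whether the lower number of compound 2 would hold with a larger group such as ethyl or methoxy in place of its methyl. They also leave open how this position would respond to an amine, a carboxylic acid or a longer chain in place of the phenyl ring.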